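Phenoxy in Place of Benzamido on a Shared Core

A few compounds are considered here, and "the series" means these few. Any claim that something is new, unique, unknown or untested is made for them only; others in the source may bear on it.

Three compounds have been measured in a functional assay on Ramos cells (Homo sapiens) for antiproliferative activity; a higher number here means a weaker inhibitor, a lower number a stronger inhibitor:
Compound 1 `Nc1ncnc2c1c(-c1cc3ccccc3o1)cn2[C@H]1CCN(C[C@H]2CO2)C1` gives 1650 nM.
Compound 2 `CC(C)(C)c1ccc(C(=O)Nc2ccc(-c3cn([C@H]4CCN(C[C@@H]5CO5)C4)c4ncnc(N)c34)cc2)cc1` gives 2970 nM.
Compound 3 `Nc1ncnc2c1c(-c1ccc(NC(=O)c3ccccc3)cc1)cn2[C@H]1CCN(C[C@@H]2CO2)C1` gives 2250 nM.

The three numbers do not separate beyond the usual scatter, so compound 3 cannot be placed above or below its neighbours. Among the compounds with values here, the only single-point step, a 1.3-fold lower number from compound 2 to compound 3 (0.12 log units; within the scatter), concerns the tert-butyl on the benzamido group and stayed within the scatter.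

Compound 4 `Nc1ncnc2c1c(-c1ccc(Oc3ccccc3)cc1)cn2[C@H]1CCN(C[C@@H]2CO2)C1` differs from compound 3 as follows: phenoxy in place of benzamido on an aromatic carbon. Within the data shown here, no measured step touches this exchange of an amide link for an ether link, so the expectation rests on the flat picture across compounds 1 to 3. The step of a 1.1-fold lower number from compound 3 to compound 4 (0.05 log units; within the scatter) is therefore expected to stay within the scatter. Compound 4 is estimated at 2000 nM, with a range from 700 nM to 6000 nM.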

Compound 4, half-maximal inhibitory concentration: 6710 nM
Beside the measured number, compound 4's estimate is 3.4-fold (0.53 log units) below it; the measured number lies above the stated range.
By their numbers in this assay, from the lowest: compounds 1, 3 and 2 (each within the scatter of the next); then compound 4.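

Within the data shown here, exchanging benzamido for phenoxy on the aromatic carbon para to a large group gives, in this assay, a 3.0-fold higher number from compound 3 to compound 4 (0.47 log units; beyond the scatter), the only step so far to pass the scatter. This position therefore responds to the group it carries, whereas the tert-butyl on the benzamido group had shown no such response. Nothing measured here accounts for the shift.

The compounds shown leave open whether the linking atoms matter or the rest of the group does. An anilino or benzyl group at this position would help separate the two.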